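Bromo in place of chloro: notes on compound 3

The source may hold more compounds than are shown below. What is called first, only, known or untested is meant among the compounds shown, and "the series" means these compounds.

Of the compounds shown here, two on a shared core have numbers so far in a physicochemical assay, with a stated time of 30 min; a higher number here means a weaker inhibitor, a lower number a stronger inhibitor. Compound 1 `CCc1ccc(NC(=O)C2Cc3cc(OC)c(OC)cc3C2=O)cc1` gives 76.2 ug/mL. Compound 2 `COc1cc2c(cc1OC)C(=O)C(C(=O)Nc1ccc(Cl)cc1)C2` gives 56.8 ug/mL. These two values lie within the scatter of each other, and compound 2 therefore holds no separate rank in this small set.

The next compound is compound 3 `COc1cc2c(cc1OC)C(=O)C(C(=O)Nc1ccc(Br)cc1)C2`, which carries bromo in place of chloro on an aromatic carbon, para to a large group: bromo in place of chloro on an aromatic carbon. The same difference reads 4-chlorophenyl to 4-bromophenyl.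

Within the data shown here, one measured step bears on this change, the exchange of ethyl for chloro on an aromatic carbon. Among the measured compounds shown here, no bromo compound has yet been measured, and this single step is a thin guide. With only a 1.3-fold lower number from compound 1 to compound 2 (0.13 log units; within the scatter) to go on, no step beyond the scatter is expected in this assay, and no direction can be favoured. The estimated outcome is a 1.0-fold lower number from compound 2 to compound 3 (0.01 log units; within the scatter). For compound 3 the expected value is 55 ug/mL, within an estimated range of 28 ug/mL to 110 ug/mL.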

Compound 3, half-maximal inhibitory concentration: 72.1 ug/mL
Compound 3: middle estimate off by 1.3-fold (0.12 log units), on the low side, and the stated range covers the measured number.
By their numbers in this assay, from the lowest: compounds 2, 3 and 1 (each within the scatter of the next).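

In this assay, the exchange at this aromatic carbon, para to a large group, gives a 1.3-fold higher number from compound 2 to compound 3 (0.10 log units; within the scatter) and so does not separate 4-bromophenyl from 4-chlorophenyl. Bromo and ethyl at the same place give a 1.1-fold lower number from compound 1 to compound 3 (0.02 log units; within the scatter) and are not separated either; with a 1.3-fold lower number from compound 1 to compound 2 (0.13 log units; within the scatter) as the earlier step, all three pairs among the ethyl, chloro and bromo compounds now lie within the scatter, so this small set of substituents offers no ranking at this position. No measurement at hand bears on why these three numbers lie so close together, and the result is recorded here without any explanation.

The compounds shown leave open whether this position would respond in this assay to a group of a different kind, such as an amine, a carboxylic acid or a longer chain, since the three groups compared here give no spread beyond the scatter to build on. They also leave open whether a change elsewhere on the shared core, for instance at the methoxy groups or the amide hydrogen, would move the number more than any exchange at this position has so far.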